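The compounds below may be only part of what the source reports. "The series", "measured", "known", "first", "only" and "open" are said of these compounds alone.

Values in an ADME assay on Raji cells (Homo sapiens) for cytotoxicity, read by luminescence, with a stated time of 72 h (on this read-out lower numbers stand for an effect already at smaller amounts and higher numbers for an effect only at larger amounts of compound), each a limit of the assay and not a number:

Compound 1 `CCOC(=O)c1c(-c2ccccc2)[nH]c2cc(OC)ccc2c1=O`: > 21500 nM
Compound 2 `CCCCOc1cccc(-c2[nH]c3cc(OC)ccc3c(=O)c2C(=O)OCC)c1`: > 21500 nM
Compound 3 `CCOC(=O)c1c(-c2cccc(Oc3ccccc3)c2)[nH]c2cc(OC)ccc2c1=O`: > 21500 nM

Compound 3 offers no number to build on, as compound 3 reads > 21500 nM, which is a limit. It shares that position with the other two, and the whole set amounts to the limit of > 21500 nM in this assay, at which 3 of the 3 values shown sit.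

Compound 4 `CCOC(=O)c1c(-c2cccc(OC(F)(F)F)c2)[nH]c2cc(OC)ccc2c1=O` differs from compound 3 by trifluoromethyl in place of phenyl on an oxygen on an aromatic ring, which turns phenoxy to trifluoromethoxy: trifluoromethyl in place of phenyl on an oxygen on an aromatic ring.

The closest measured change sits on the same oxygen, phenyl in place of butyl, and it is a step that the two limits leave unreadable from compound 2 to compound 3. Adding phenoxy in place of hydrogen on an aromatic carbon gives a step that the two limits leave unreadable from compound 1 to compound 3, while adding butoxy in its place gives a step that the two limits leave unreadable from compound 1 to compound 2. None of these steps has a readable size, so none supplies a magnitude or a direction to carry over. With all three compounds at the limit, no step beyond the scatter is expected in this assay, and a report of the same limit is the likeliest outcome.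

The expected change is a step that the limit leaves unreadable from compound 3 to compound 4. Compound 4 is estimated at 25000 nM, with an expected range from 12000 nM to 50000 nM.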

Compound 4, half-maximal effective concentration: > 21500 nM
Compound 4: a limit, no number; the forecaster's own chance of this, stated with the estimate: 85%; the middle value does not contradict the limit.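

In this assay, among these compounds, compound 4 reads as a limit and not a number, so no step between it and compound 1, compound 2 or compound 3 can be read: the limit of > 21500 nM in this assay, at which 4 of the 4 values shown sit.

The compounds shown leave open what number any of the four would give and whether swapping these groups on the oxygen changes that number at all.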